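Chloro for Trifluoromethyl on a Kinase Inhibitor Scaffold

The compounds below may be only part of what the source reports. "The series", "measured", "known", "first", "only" and "open" are said of these compounds alone.

Within the data shown here, compound 1 `O=c1ccc(-c2ccc3cn[nH]c3c2)cn1Cc1cccc(C(F)(F)F)c1` is the one compound here with a measured number: in an assay for inhibition of MAP kinase-interacting serine/threonine-protein kinase 1 (Homo sapiens), read by luminescence and ADP-Glo, with a stated time of 2 h (a higher number here means a weaker inhibitor, a lower number a stronger inhibitor), compound 1 gives 40 nM. Compound 2 `Cn1cc2ccc(-c3ccc(=O)n(Cc4ccccc4)c3)cc2n1`, built on a different core, gives in this assay only > 2000 nM, which is a limit of the assay rather than a number (the limit of > 2000 nM in this assay, at which 1 of the 2 values shown sits). Compound 3 `O=c1ccc(-c2ccc3cn[nH]c3c2)cn1Cc1cccc(Cl)c1` keeps the core of compound 1 and differs in one place: chloro in place of trifluoromethyl on an aromatic carbon. No change of this kind has been measured among these compounds, so only a small step, toward weaker inhibition, is expected in this assay: a 2.0-fold higher number from compound 1 to compound 3 (0.30 log units; within the scatter). Compound 3 is therefore expected to give about 80 nM, within 25 nM to 250 nM.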

Compound 3, half-maximal inhibitory concentration: 37 nM
For compound 3 the middle estimate is 2.2-fold (0.33 log units) above the measured one; low and high end bracket the measured number.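

Chloro in place of trifluoromethyl on this aromatic carbon gives a 1.1-fold lower number from compound 1 to compound 3 (0.03 log units; within the scatter) in this assay so the two compounds read alike. At this position, one heavy atom can stand where four stood without moving the number beyond the scatter. Nothing shown here explains why these two groups read alike. Going by these compounds, whether the position also accepts an amine, a carboxylic acid or a longer chain stays open. So does whether the core of compound 1 needs any group here, which plain hydrogen at this carbon would test.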